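Swapping the Aryl Group on the Hydrazone Carbon

This account rests on a few compounds, and the source may have more. Where it says the series, first, only, none or still open, it means among the compounds named here.

Of the compounds shown here, three sharing one core have been measured in a functional assay on HT-29 cells (Homo sapiens) for cytotoxicity, read by MTT assay, with a stated time of 72 h; on this read-out lower numbers stand for stronger inhibition and higher numbers for weaker inhibition. Compound 1 `COc1ccc(OC)c(/C=N/NC(=O)Nc2ccc(Oc3ccnc(-c4nncn4CCN(C)C)c3)c(F)c2)c1` gives 2070 nM, compound 2 `CN(C)CCn1cnnc1-c1cc(Oc2ccc(NC(=O)N/N=C/c3cccc(Br)c3)cc2F)ccn1` gives 380 nM, and compound 3 `CN(C)CCn1cnnc1-c1cc(Oc2ccc(NC(=O)N/N=C/c3ccc(Cl)cc3)cc2F)ccn1` gives 530 nM. Compound 3 thus stands second highest of the three, with a 3.9-fold lower number from compound 1 to compound 3 (0.59 log units; beyond the scatter) beyond the scatter and a 1.4-fold higher number from compound 2 to compound 3 (0.14 log units; within the scatter) within it. Compound 4 `CN(C)CCn1cnnc1-c1cc(Oc2ccc(NC(=O)N/N=C/c3ccc(O)c(F)c3)cc2F)ccn1` differs from compound 3 by 3-fluoro-4-hydroxyphenyl in place of 4-chlorophenyl on a carbon with a double bond to nitrogen. Within the data shown here, the two steps that bear on this position, a 5.4-fold lower number from compound 1 to compound 2 (0.74 log units; beyond the scatter) and a 3.9-fold lower number from compound 1 to compound 3 (0.59 log units; beyond the scatter), show that the group here can move the number by a modest amount, yet no measured compound carries a 3-fluoro-4-hydroxyphenyl group. An expected step of a 1.3-fold higher number from compound 3 to compound 4 (0.12 log units; within the scatter) seems reasonable, small and uncertain in direction. Compound 4 is therefore estimated at 700 nM, with a range from 250 nM to 2000 nM.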

Compound 4, half-maximal inhibitory concentration: 3310 nM
The estimate for compound 4 lay 4.7-fold (0.67 log units) below the measured number; measured number above the stated range.
By their numbers in this assay, from the lowest: compounds 2 and 3 (each within the scatter of the next); then compounds 1 and 4 (each within the scatter of the next).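

With 3-fluoro-4-hydroxyphenyl in this place, the group on the carbon with a double bond to nitrogen proves able to undo the gain seen with the halogen-only rings: there is a 6.2-fold higher number from compound 3 to compound 4 (0.80 log units; beyond the scatter) and an 8.7-fold higher number from compound 2 to compound 4 (0.94 log units; beyond the scatter). Against the 2,5-dimethoxyphenyl group, the step is a 1.6-fold higher number from compound 1 to compound 4 (0.20 log units; within the scatter), so among these four compounds, the two rings bearing oxygen sit together at the high end. No measurement here explains this split. Still open, as far as these compounds go, is whether the hydroxy group or the fluorine drives the step, and how an amine or a carboxylic acid on this ring would read.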